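Replacing the piperidine amide in a nitro sulfone series

This account rests on a few compounds, and the source may have more. Where it says the series, first, only, none or still open, it means among the compounds named here.

Compound 1, `CC1CCN(C(=O)CN(C)C(=O)c2ccc(S(C)(=O)=O)c([N+](=O)[O-])c2)CC1`, gives > 60000 nM in an assay on isolated protein for inhibition of thyroid hormone receptor beta (Homo sapiens), read by fluorescence polarization (a higher number here means a weaker inhibitor, a lower number a stronger inhibitor), and that value is a limit of the assay rather than a number.
Compound 2, `CS(=O)(=O)c1ccc(C(=O)NCCCC(=O)N2Cc3ccccc3C2)cc1[N+](=O)[O-]`, gives > 60000 nM in this assay, again a limit.
Compound 3, `CC1CCN(C(=O)CCNC(=O)c2ccc(S(C)(=O)=O)c([N+](=O)[O-])c2)CC1`, gives > 60000 nM in this assay, again a limit.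

All three measured compounds share the same core and none reaches a measurable value; compound 1 stands where the other two stand, at the limit of > 60000 nM in this assay, at which 3 of the 3 values shown sit. Going by the values given here, no pair of measured compounds differs in a single place, so no measured step is available from which a size could be read.

Compound 4, `CCCN(C(=O)CN(C)C(=O)c1ccc(S(C)(=O)=O)c([N+](=O)[O-])c1)c1ccccc1`, is related to compound 1 by phenyl(propyl)amino in place of 4-methylpiperidin-1-yl on a carbonyl carbon. Since compound 1 itself sits at the limit, there is no number from which a step could be measured, and the three compounds give no sign that changes around the amide move the read-out. The step from compound 1 to compound 4 is therefore expected to be none beyond the scatter, a number no higher from compound 1 to compound 4 (the limit leaves the size open), with the most likely outcome another limit. For compound 4 the estimate in this assay is 60000 nM, expected to lie between 15000 nM and 200000 nM.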

Compound 4, half-maximal inhibitory concentration: > 60000 nM
Compound 4: a limit, no number (the forecaster's own chance of this, stated with the estimate: 75%); the middle value lies on the limit itself.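

Compound 1 and compound 4 both give a limit of the assay rather than a number, so no step can be read between them. The compounds shown sit together: the limit of > 60000 nM in this assay, at which 4 of the 4 values shown sit.

They leave open whether any change around the amide on the shared core can give a measurable value in this assay.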